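A few compounds are considered here, and "the series" means these few. Any claim that something is new, unique, unknown or untested is made for them only; others in the source may bear on it.

Working notes on the series.

Compound 1 `COc1ccc(C(=O)NNC(=O)c2ccc3[nH]c(-c4ccc([N+](=O)[O-])o4)nc3c2)cc1OC` sits at the low end of the two numbers available: in a functional assay on HT-29 cells (Homo sapiens) for inhibition, read by sulforhodamine B assay, with a stated time of 48 h (on this read-out lower numbers stand for stronger inhibition of growth and higher numbers for weaker inhibition of growth), compound 1 gives 15.6 ug/mL. Among the measured compounds shown here, compound 2 `O=C(NNC(=O)c1cc2ccccc2cc1O)c1ccc2[nH]c(-c3ccc([N+](=O)[O-])s3)nc2c1` differs from it in more than one place, so no single step can be drawn between them; in this assay compound 2 gives 62.5 ug/mL, a higher number than that of compound 1 by a gap beyond the usual scatter.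

Compound 3 `COc1cc(C(=O)NNC(=O)c2ccc3[nH]c(-c4ccc([N+](=O)[O-])o4)nc3c2)cc(OC)c1OC` differs from compound 1 by methoxy in place of hydrogen on an aromatic carbon. For the measured compounds named here, no measured pair isolates this kind of change, so the expected step rests on the pattern of compound 1 alone; the expectation is for a step of small size, if any, and not clearly beyond the scatter, with a slight lean toward a lower number.

Compound 3 is therefore estimated at 12 ug/mL, with a range from 5 ug/mL to 30 ug/mL, corresponding to an expected step of a 1.3-fold lower number from compound 1 to compound 3 (0.11 log units; within the scatter).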

Compound 3, concentration for 50% growth inhibition: 31.3 ug/mL
For compound 3 the middle estimate is 2.6-fold (0.42 log units) below the measured one; measured number above the stated range.
By their numbers in this assay, from the lowest: compounds 1, 3 and 2 (each within the scatter of the next, the first and the last beyond it).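

In this assay, methoxy in place of hydrogen on an aromatic carbon, ortho to a methoxy group and meta to a large group, gives a 2.0-fold higher number from compound 1 to compound 3 (0.30 log units; within the scatter), the only single-place step shown in the series. Compound 1 and compound 3 therefore cannot be told apart on this read-out, so this position accepts methoxy with no difference that can be separated from the scatter. No measurement shown here bears on the reason for the size of this step.

Going by these compounds, whether an amine, a carboxylic acid or a longer alkoxy chain at this position would give a step beyond the scatter remains open. Also open, on these data alone, is how methoxy behaves on the other carbons of this ring, and the contribution of each difference between compound 2 and the other two compounds cannot be read.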